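Hydrazone aryl swaps on the anilino-triazine sulfonamide series

The compounds below may be only part of what the source reports. "The series", "measured", "known", "first", "only" and "open" are said of these compounds alone.

Compound 1 `NS(=O)(=O)c1ccc(Nc2nc(N/N=C/c3ccc(C(F)(F)F)cc3)nc(Nc3ccccc3)n2)cc1` – 40600 nM in a functional assay on SNB-19 cells (Homo sapiens) for inhibition, read by sulforhodamine B assay, with a stated time of 48 h; a lower number here means that less compound is tolerated, a higher number that more compound is tolerated
Compound 2 `Cc1nn(-c2ccccc2)cc1/C=N/Nc1nc(Nc2ccccc2)nc(Nc2ccc(S(N)(=O)=O)cc2)n1` – > 100000 nM in this assay

The value of compound 2 is a limit of this assay, not a number (the limit of > 100000 nM in this assay, at which 1 of the 2 values shown sits). The step of an at least 2.4-fold higher number from compound 1 to compound 2 (0.39 log units; beyond the scatter) therefore gives only a lower bound. Compound 3 `NS(=O)(=O)c1ccc(Nc2nc(N/N=C/c3ccccn3)nc(Nc3ccccc3)n2)cc1` carries pyridin-2-yl in place of 3-methyl-1-phenyl-1H-pyrazol-4-yl on a carbon with a double bond to nitrogen. Among the measured compounds shown here, only that one measured step bears on this change, and it points to the pyrazolyl compound 2 tolerating more compound than compound 1. With pyridin-2-yl the number for compound 3 is expected near compound 1, 60000 nM (range 20000 nM to 150000 nM), an estimated step of an at least 1.6-fold lower number from compound 2 to compound 3 (0.22 log units; that floor lies within the scatter) from the limit.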

Compound 3, concentration lethal to 50% of the cells: > 100000 nM
Compound 3 was reported as a limit; the forecaster's own chance of this, stated with the estimate: 40%; at least 1.6-fold (0.22 log units) between middle value and limit.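

In this assay compound 3 also sits at a limit, > 100000 nM, not a number. Pyridin-2-yl in place of 4-(trifluoromethyl)phenyl on the carbon with a double bond to nitrogen gives an at least 2.4-fold higher number from compound 1 to compound 3 (0.39 log units; beyond the scatter), so a second group, with a single six-membered ring, now gives a lower bound like that of the pyrazolyl group. The step between compound 2 and compound 3 cannot be read, and compound 1 remains the only one with a measured number: the limit of > 100000 nM in this assay, at which 2 of the 3 values shown sit.

From the compounds shown here alone, how far compound 2 and compound 3 lie past that limit remains open. Also open, going by these compounds, is whether a phenyl group carrying an amine or a carboxylic acid at this place would give a readable number.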